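The source may report more compounds than this note shows. Statements on the series, on what has been measured and on what is new or still open speak of the compounds shown alone.

In a functional assay on HeLa cells (Homo sapiens) for antiproliferative activity, with a stated time of 24 h (on this read-out higher numbers stand for weaker inhibition and lower numbers for stronger inhibition), compound 1 `Cc1ccccc1CN1CCc2c(sc(NC(=O)c3ccccc3Cl)c2C(N)=O)C1`, compound 2 `NC(=O)c1c(NC(=O)c2ccccc2Cl)sc2c1CCN(Cc1ccccc1Cl)C2` and compound 3 `NC(=O)c1c(NC(=O)c2ccccc2Cl)sc2c1CCN(Cc1ccccc1F)C2` share one core and differ in a single group. Compound 3 gives > 50000 nM, which is a limit and not a number, and this is the limit of > 50000 nM in this assay, at which 2 of the 3 values shown sit. Compound 1 gives > 50000 nM, also a limit. Only compound 2 gives a number, 27500 nM.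

Compound 4 `NC(=O)c1c(NC(=O)c2ccccc2Cl)sc2c1CCN(Cc1c(Cl)cccc1Cl)C2` differs from compound 3 in one place: 2,6-dichlorophenyl in place of 2-fluorophenyl on a saturated chain carbon bound to an amine nitrogen in a ring. In words, 2,6-dichlorophenyl stands in place of 2-fluorophenyl on a saturated chain carbon bound to an amine nitrogen in a ring.

The measured steps that bear on this are an at least 1.8-fold higher number from compound 2 to compound 3 (0.25 log units; that floor lies within the scatter) and an at least 1.8-fold lower number from compound 1 to compound 2 (0.25 log units; that floor lies within the scatter). Neither floor goes beyond the scatter, so they offer only a weak hint that chloro goes with a lower number. Compound 4 carries chloro, so a modest move in that direction is expected, and another reading at the limit remains possible. The expected change is an at least 2.0-fold lower number from compound 3 to compound 4 (0.30 log units; that floor lies within the scatter). The estimated value for compound 4 is 25000 nM, with an expected range from 8000 nM to 50000 nM.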

Compound 4, half-maximal inhibitory concentration: 28800 nM
Compound 4: middle estimate off by 1.2-fold (0.06 log units), on the low side; measured number inside the range.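

In this assay, both compounds with chloro on the benzyl group now give a number, and the second chloro adds nothing this read-out can separate: a 1.0-fold higher number from compound 2 to compound 4 (0.02 log units; within the scatter). Against the 2-fluorophenyl and 2-methylphenyl groups, the steps read an at least 1.7-fold lower number from compound 3 to compound 4 (0.23 log units; that floor lies within the scatter) and an at least 1.7-fold lower number from compound 1 to compound 4 (0.23 log units; that floor lies within the scatter), so even the 2,6-dichlorophenyl group gives no gap shown to exceed the scatter. These two steps remain floors, not measured sizes, because the other two compounds sit at a limit: the limit of > 50000 nM in this assay, at which 2 of the 4 values shown sit.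

Going by these compounds, it remains open whether any group on this saturated chain carbon can move the number well beyond the scatter, for example an amine or a carboxylic acid in place of the 2,6-dichlorophenyl group. A longer chain in place of the benzyl carbon is equally untested by these compounds.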